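Free pyrazole replaces acetylpyrazole in an antiproliferative series

The source may report more compounds than this note shows. Statements on the series, on what has been measured and on what is new or still open speak of the compounds shown alone.

Of the compounds shown here, three sharing one core have been measured in a functional assay on MV4-11 cells (Homo sapiens) for antiproliferative activity, with a stated time of 6 days, tested at 1.56 uM; on this read-out higher numbers stand for a stronger effect at the one concentration tested and lower numbers for a weaker effect. Compound 1 `CNC(=O)N1CCCc2ccc(NC(=O)c3ccc(-c4ccccc4)cc3)cc21` gives 19.7%. Compound 2 `CNC(=O)N1CCCc2ccc(NC(=O)c3ccc(-c4cnn(C(C)=O)c4)cc3)cc21` gives 23.9%. Compound 3 `CNC(=O)N1CCCc2ccc(NC(=O)c3ccc(-c4ccn(C(C)=O)n4)cc3)cc21` gives 35.8%, the highest of the three numbers; its step from compound 2 is a number 11.9 percentage points higher from compound 2 to compound 3 (beyond the scatter), and from compound 1 the step is a number 16.1 percentage points higher from compound 1 to compound 3 (beyond the scatter). The step of a number 4.2 percentage points higher from compound 1 to compound 2 (within the scatter) lies within the scatter.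

Compound 4 `CNC(=O)N1CCCc2ccc(NC(=O)c3ccc(-c4cn[nH]c4)cc3)cc21` has not yet been measured. It differs from compound 3 in one place: 1H-pyrazol-4-yl in place of 1-acetyl-1H-pyrazol-3-yl on an aromatic carbon. Two of the measured steps bear on this change. The step of a number 11.9 percentage points higher from compound 2 to compound 3 (beyond the scatter) shows that moving from the 1-acetyl-1H-pyrazol-4-yl to the 1-acetyl-1H-pyrazol-3-yl raised the read-out; compound 4 returns to a pyrazol-4-yl attachment, so a drop of similar size is expected, while removal of the acetyl group is not covered by any measured step. The step from compound 3 to compound 4 in this assay is therefore estimated at a number 11.8 percentage points lower from compound 3 to compound 4 (beyond the scatter). Compound 4 is expected to give about 24%, within a range of 8% to 42%.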

Compound 4, a percentage reported as inhibition, at one concentration (the size of the read-out at that concentration, not a potency): 73.5%
For compound 4 the middle estimate is 49.5 percentage points below the measured one, and the stated range ends below it.
By their numbers in this assay, from the lowest: compounds 1 and 2 (each within the scatter of the next); then compound 3; then compound 4.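

In this assay, within the data shown here, hydrogen in place of acetyl on the aromatic nitrogen gives a number 49.6 percentage points higher from compound 2 to compound 4 (beyond the scatter) and so shows, for the first time, that this acetyl group strongly affects the read-out at this position. The 1H-pyrazol-4-yl also exceeds the best acetylated ring, with a number 37.7 percentage points higher from compound 3 to compound 4 (beyond the scatter) on that change, and it stands well clear of the plain aromatic ring, with a number 53.8 percentage points higher from compound 1 to compound 4 (beyond the scatter) in place of phenyl. The results come with no information that would explain these rises.

On these data alone, it remains open whether an unacetylated 1H-pyrazol-3-yl would match or exceed the 1H-pyrazol-4-yl, which would separate the effect of the attachment point from that of the free ring nitrogen. Also open, as far as these compounds go, is whether a methyl group on that nitrogen, or an imidazole or triazole ring in place of the pyrazole, would keep the read-out this high.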